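A few compounds are considered here, and "the series" means these few. Any claim that something is new, unique, unknown or untested is made for them only; others in the source may bear on it.

Compound 2 `CC(C)(C)CC(=O)N1CCC[C@H]1C(=O)N1CCC(NS(=O)(=O)c2cc(S(=O)(=O)c3ccccc3)ccc2C(F)(F)F)CC1` and compound 1 `O=C1CC[C@@H](C(=O)N2CCC(NS(=O)(=O)c3cc(S(=O)(=O)c4ccccc4)ccc3C(F)(F)F)CC2)N1` share one core and differ only in the group on a carbonyl carbon. In a physicochemical assay for solubility (on this read-out higher numbers stand for higher solubility and lower numbers for lower solubility), compound 1 gives 100000 nM, while compound 2 gives 25000 nM. Going by the values given here, compound 2 thus holds the lowest of the two numbers measured so far, and the only measured step, a 4.0-fold lower number from compound 1 to compound 2 (0.60 log units; beyond the scatter), sets it apart from compound 1 by a margin beyond the scatter.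

Compound 3 `CN(C)C(=O)N1CCC[C@H]1C(=O)N1CCC(NS(=O)(=O)c2cc(S(=O)(=O)c3ccccc3)ccc2C(F)(F)F)CC1` takes the next step from compound 2: dimethylamino in place of neopentyl on a carbonyl carbon. The measured step from compound 1 to compound 2 is the only one available and concerns a different exchange, so it bears on this step only loosely. Given that the neopentyl group entered in that step together with a drop in this assay, its removal in favour of dimethylamino is expected to bring a modest gain, a 2.0-fold higher number from compound 2 to compound 3 (0.30 log units; within the scatter), though the data offer no direct precedent. Compound 3 is therefore estimated to give 50000 nM in this assay, within a range from 20000 nM to 125000 nM.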

Compound 3, solubility: 100000 nM
Beside the measured number, compound 3's estimate is 2.0-fold (0.30 log units) below it, within the range that was stated.
By their numbers in this assay, from the lowest: compound 2; then compounds 1 and 3 (each within the scatter of the next).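

Going by these compounds alone, on a carbonyl carbon whose other neighbour is an amide-type nitrogen in a ring, the exchange of neopentyl for dimethylamino gives a 4.0-fold higher number from compound 2 to compound 3 (0.60 log units; beyond the scatter) in this assay and is the first direct reading of what these two groups do at this place. The second step, with 1-(dimethylcarbamoyl)pyrrolidin-2-yl in place of 5-oxopyrrolidin-2-yl, gives no change at the digits printed from compound 1 to compound 3 (within the scatter) and so shows that a group substituted on the pyrrolidine nitrogen does not in itself go with a lower number, since among these three compounds only compound 2, with neopentyl, stands apart. Nothing measured here accounts for the difference between neopentyl and dimethylamino.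

The compounds shown leave open whether a longer chain such as diethylamino, a ring amine such as morpholine or a carboxylic acid on this carbonyl carbon would read like compound 2 or like compound 3 in this assay and whether neopentyl is a special case. They also leave open whether the same exchange would give a similar step on a different core.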